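This account rests on a few compounds, and the source may have more. Where it says the series, first, only, none or still open, it means among the compounds named here.

Measured so far in a functional assay (aorta) with Rattus norvegicus as the target; a higher number here means a more potent compound, by a factor of ten per unit of this negative logarithm, a lower number a less potent compound:
compound 1 `CC1(C)C=C(n2ccccc2=O)c2ccccc2O1` gives 5.43
compound 2 `Cc1ccc(C)n1-c1ccc2c(c1)C(n1ccccc1=O)=CC(C)(C)O2` gives 7.27
compound 3 `CC1(C)C=C(n2ccccc2=O)c2cc(OS(=O)(=O)F)ccc2O1` gives 7.95

Compound 3 stands highest of the three, with compound 2 nearest and compound 1 furthest. Compound 4 `CC1(C)C=C(n2ccccc2=O)c2cc(-c3ccncc3)ccc2O1` is not yet measured and differs from compound 3 in one place: pyridin-4-yl in place of (fluorosulfonyl)oxy on an aromatic carbon. Among the measured compounds shown here, two steps bear on this. The steps of a number 2.52 log units higher from compound 1 to compound 3 (beyond the scatter) and a number 1.84 log units higher from compound 1 to compound 2 (beyond the scatter) show that either group at this position raises the number strongly over hydrogen, while the step of a number 0.68 log units higher from compound 2 to compound 3 (beyond the scatter) shows the pyrrole ring giving less than the sulfonyl group. Pyridin-4-yl is an aromatic ring, like the group in compound 2, which gives 7.27; compound 4 is therefore expected to land between compound 2 and compound 3. For compound 4 the expected step is a number 0.55 log units lower from compound 3 to compound 4 (beyond the scatter). The estimate for compound 4 is 7.4, range 6.7 to 8.1.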

Compound 4, logarithm of the reciprocal of the active concentration, log(1/C): 6.68
Beside the measured number, compound 4's estimate is 0.72 log units above it; the measured number lies below the stated range.
By their numbers in this assay, from the lowest: compound 1; then compound 4; then compound 2; then compound 3.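

In this assay an aromatic ring on this carbon does not by itself reach the level of the (fluorosulfonyl)oxy group, with pyridin-4-yl giving a number 1.27 log units lower from compound 3 to compound 4 (beyond the scatter). The two aromatic rings are also not interchangeable: the change from 2,5-dimethyl-1H-pyrrol-1-yl to pyridin-4-yl gives a number 0.59 log units lower from compound 2 to compound 4 (beyond the scatter). Pyridin-4-yl still keeps a clear gain over hydrogen, at a number 1.25 log units higher from compound 1 to compound 4 (beyond the scatter), although no measured evidence here accounts for the order among these groups.

On these data alone, whether an amine, a carboxylic acid or a nitrile on this carbon would match compound 3 remains open. Also open, as far as these compounds go, is how pyridin-3-yl or phenyl would compare with compound 4.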